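Benzimidazole amides at the assay ceiling: a pyrazole swap

The source may hold more compounds than are shown below. What is called first, only, known or untested is meant among the compounds shown, and "the series" means these compounds.

Compound 1 `CCn1nc(C)cc1C(=O)Nc1nc2cc(C(N)=O)cc(OC)c2n1CCCNC(=O)OCc1ccccc1` gives > 100000 nM in an assay for activation of interferon regulatory factor 3 (Homo sapiens), read by a luciferase reporter, with a stated time of 20 h; a lower number here means that less compound is needed, a higher number that more compound is needed for the effect; this is a limit.
Compound 2 `CCCn1c(NC(=O)c2cc(C)nn2CC)nc2cc(C(=O)OC)cc(OC)c21` gives > 100000 nM in this assay; this is a limit.
Compound 3 `CCCn1c(NC(=O)c2ccccn2)nc2cc(C(N)=O)cc(OC)c21` gives > 100000 nM in this assay; this is a limit.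

Compound 3 stands at the limit of this assay, so no number is known for it, only that it lies beyond what the assay reports. The same holds for every measured value here, as the limit of > 100000 nM in this assay, at which 3 of the 3 values shown sit, shows. Compound 4 `CCCn1c(NC(=O)c2ccnn2CC)nc2cc(C(N)=O)cc(OC)c21` differs from compound 3 by 1-ethyl-1H-pyrazol-5-yl in place of pyridin-2-yl on a carbonyl carbon. For the measured compounds named here, since no measured step between compounds is available, the direction of the change cannot be read from data; with all three measured values at the limit, no step beyond the scatter is expected, and the expected step of a number no higher from compound 3 to compound 4 (the limit leaves the size open) is essentially none. Compound 4 is therefore expected to give about 100000 nM, in the range 20000 nM to 300000 nM.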

Compound 4, half-maximal effective concentration: > 100000 nM
Compound 4 gave a limit, no number; the forecaster's own chance of this, stated with the estimate: 85%; the middle value sits exactly at the limit.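

Compound 3 and compound 4 both stand at a limit in this assay, so no step can be read between them: the limit of > 100000 nM in this assay, at which 4 of the 4 values shown sit.

The compounds shown leave open which structure, if any, would give a readable number in this assay.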